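This account rests on a few compounds, and the source may have more. Where it says the series, first, only, none or still open, it means among the compounds named here.

Measured compounds:
Compound 1, `N=C(NCCCc1c[nH]cn1)NCCC(c1ccc(C(F)(F)F)cc1)c1ccccn1`; in a functional assay on ileum for antagonist activity at histamine H1 receptor (Cavia porcellus) (a lower number here means tighter binding, a higher number weaker binding), compound 1 gives 282 nM.
Compound 2, `N=C(NCCCc1c[nH]cn1)NCCC(c1cc(F)cc(F)c1)c1ccccn1`; in this assay compound 2 gives 275 nM.

Compound 2 carries a 3,5-difluorophenyl group on the saturated chain carbon that also bears a pyridin-2-yl group. Its number in this assay sits next to that of compound 1, and the two values lie within the scatter of each other, so neither can be called tighter or weaker on these data: a 1.0-fold lower number from compound 1 to compound 2 (0.01 log units; within the scatter).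

Compound 3, `N=C(NCCCc1c[nH]cn1)NCCC(c1ccccn1)c1ccccn1`, is not yet measured. It differs from compound 2 in one place: pyridin-2-yl in place of 3,5-difluorophenyl on a saturated chain carbon bound to an aromatic carbon and a saturated chain carbon. For the measured compounds named here, the only step measured so far swaps one carbon-only aromatic ring for another on that same chain carbon and leaves the number unchanged within the scatter. Going by the values given here, the change to compound 3 brings in a ring with a nitrogen instead, for which no step is known, so the step is expected to be small but uncertain, a 1.3-fold higher number from compound 2 to compound 3 (0.10 log units; within the scatter).

Compound 3 is therefore estimated at 350 nM in this assay, with a range from 120 nM to 1000 nM.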

Compound 3, dissociation constant: 389 nM
Beside the measured number, compound 3's estimate is 1.1-fold (0.05 log units) below it; measured number inside the range.
By their numbers in this assay, from the lowest: compounds 2, 1 and 3 (each within the scatter of the next).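

For the compounds shown here, the earlier pair compared only two carbon-only aromatic rings on this saturated chain carbon, so compound 3 is the first to test a ring with a nitrogen there, and with it a hydrogen-bond acceptor where the rings it replaces have none. In this assay, replacing 3,5-difluorophenyl with pyridin-2-yl gives a 1.4-fold higher number from compound 2 to compound 3 (0.15 log units; within the scatter), and replacing 4-(trifluoromethyl)phenyl with pyridin-2-yl gives a 1.4-fold higher number from compound 1 to compound 3 (0.14 log units; within the scatter), so the three numbers cannot be told apart and this position tolerates all three rings, including one that has no fluorine at all. No measurement shown here bears on why these swaps make no difference beyond the scatter.

All three compounds keep an aromatic ring of six atoms in this place, so the data say nothing about how far this tolerance extends to something quite different, such as a saturated cyclohexyl ring, a small methyl group, an amine or a carboxylic acid. A swap of that kind on the same saturated chain carbon would show whether an aromatic ring is needed there at all.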